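The source may report more compounds than this note shows. Statements on the series, on what has been measured and on what is new or still open speak of the compounds shown alone.

Measured so far: compound 1 `c1cn2cc(-c3ccsc3)nc(-c3ccc4ncn(C5CCCCC5)c4c3)c2n1` gives 4.9% in a functional assay on LOX IMVI cells (Homo sapiens) for inhibition, read by sulforhodamine B assay, with a stated time of 48 h, tested at 10 uM; on this read-out higher numbers stand for more inhibition at the one concentration tested (going by the name of the read-out) and lower numbers for less inhibition. Compound 2 `CCc1ccc(-c2cn3ccnc3c(-c3ccc4ncn(Cc5ccccc5)c4c3)n2)cc1` gives 50.2% in this assay.

Compound 2 stands highest of the two numbers, with compound 1 the nearest, a gap beyond the scatter. Among the compounds with values here, no step between the measured compounds is recorded, so the two values show only that compound 2 lies well above compound 1 in this assay.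

Compound 3 `Cc1cccc(-c2cn3ccnc3c(-c3ccc4ncn(Cc5ccccc5)c4c3)n2)c1` differs from compound 2 by 3-methylphenyl in place of 4-ethylphenyl on an aromatic carbon. The expected step in this assay is a number 10.2 percentage points lower from compound 2 to compound 3 (beyond the scatter), a modest loss or none beyond the scatter. Compound 3 is estimated at 40%, within 15% to 65%.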

Compound 3, a percentage reported as inhibition, at one concentration (the size of the read-out at that concentration, not a potency): 14.8%
Estimate against measurement, compound 3: 25.2 percentage points above; measured number outside the range, below it.
By their numbers in this assay, from the lowest: compounds 1 and 3 (each within the scatter of the next); then compound 2.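

At this aromatic carbon, 3-methylphenyl in place of 4-ethylphenyl gives a number 35.4 percentage points lower from compound 2 to compound 3 (beyond the scatter) in this assay, so the number responds strongly to a change confined to the substituent on the phenyl ring. The change alters both the chain and its place on that ring, and this pair cannot separate the two. Nothing measured here bears on the reason for the step.

The compounds shown leave open how 4-methylphenyl or 3-ethylphenyl would read at this position. Also open, from the compounds shown here alone, is whether an amine or a longer chain on the phenyl ring would hold the number.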